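The compounds below may be only part of what the source reports. "The series", "measured", "known", "first", "only" and "open" are said of these compounds alone.

Measured so far in a functional assay on HepG2 cells (Homo sapiens) for cytotoxicity, read by MTT assay, with a stated time of 48 h; on this read-out lower numbers stand for stronger inhibition and higher numbers for weaker inhibition:
compound 1 `O=C1/C(=C\c2ccc([N+](=O)[O-])cc2)S/C(=N/c2ccccc2)N1Cc1ccncc1` gives 18900 nM
compound 2 `CN(C)c1ccc(/C=C2/S/C(=N/c3ccccc3)N(Cc3ccncc3)C2=O)cc1` gives 52600 nM

Compound 2 holds the highest number of the two; its nearest neighbour is compound 1, and the step between them, a 2.8-fold higher number from compound 1 to compound 2 (0.44 log units; beyond the scatter), is modest but beyond the scatter. Compound 3 `COc1ccc(/C=C2/S/C(=N/c3ccccc3)N(Cc3ccncc3)C2=O)cc1OC` is not yet measured. It differs from compound 2 in one place: 3,4-dimethoxyphenyl in place of 4-(dimethylamino)phenyl on a double-bonded chain carbon bound to a double-bonded ring carbon. Going by the values given here, no measured step covers this particular exchange; the only step in hand, a 2.8-fold higher number from compound 1 to compound 2 (0.44 log units; beyond the scatter), shows that swapping the group on the pendant aromatic ring shifts the number by a modest amount, so a step of similar size in either direction is plausible, and none beyond the scatter cannot be ruled out. On that basis the expected step is a 1.3-fold lower number from compound 2 to compound 3 (0.12 log units; within the scatter). For compound 3 the estimate in this assay is 40000 nM, within a range from 15000 nM to 110000 nM.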

Compound 3, half-maximal inhibitory concentration: 28900 nM
The estimate for compound 3 lay 1.4-fold (0.14 log units) above the measured number; the range from low to high includes it.
By their numbers in this assay, from the lowest: compounds 1, 3 and 2 (each within the scatter of the next, the first and the last beyond it).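

In this assay, 3,4-dimethoxyphenyl at this place, on a double-bonded chain carbon bound to a double-bonded ring carbon, gives a number that cannot be separated from either earlier compound: a 1.8-fold lower number from compound 2 to compound 3 (0.26 log units; within the scatter), and a 1.5-fold higher number from compound 1 to compound 3 (0.18 log units; within the scatter). The earlier step between 4-nitrophenyl and 4-(dimethylamino)phenyl therefore does not divide the series into two separate levels, since compound 3 stands within the scatter of both. Going by these compounds alone, with this third aromatic group, exchanges at this place have so far produced only one step beyond the scatter, the one between compound 1 and compound 2. Nothing available explains these numbers.

From the compounds shown here alone, it remains open whether a carboxylic acid or a primary amine on the aromatic ring would move the number further at this place. Going by these compounds, the effect of replacing the phenyl ring itself with a pyridine ring or a saturated cyclohexyl ring also remains open.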